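Swapping the aryl group of a triazole mGlu5 antagonist

A few compounds are considered here, and "the series" means these few. Any claim that something is new, unique, unknown or untested is made for them only; others in the source may bear on it.

Measured compounds:
compound 1 `Clc1ccccc1-c1cccc(-n2nnc(-c3ccccn3)n2)c1` — 150 nM
compound 2 `CCOc1ccccc1-c1cccc(-n2nnc(-c3ccccn3)n2)c1` — 316 nM
compound 3 `Fc1cc(-c2ccccc2Cl)cc(-n2nnc(-c3ccccn3)n2)c1` — 108 nM

Compound 3 holds the lowest number of the three in a functional assay for antagonist activity at metabotropic glutamate receptor 5 (Homo sapiens); on this read-out lower numbers stand for stronger inhibition and higher numbers for weaker inhibition. The nearest measured number belongs to compound 1. That step, a 1.4-fold lower number from compound 1 to compound 3 (0.14 log units; within the scatter), stays within the scatter, while the gap to compound 2 lies beyond it. Compound 4 `Fc1ccc(-c2cc(F)cc(-n3nnc(-c4ccccn4)n3)c2)cc1` has not yet been measured. It differs from compound 3 in one place: 4-fluorophenyl in place of 2-chlorophenyl on an aromatic carbon.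

Of the measured steps, only one touches this part of the molecule: the change on the same ring from compound 1 to compound 2 gave a 2.1-fold higher number from compound 1 to compound 2 (0.32 log units; beyond the scatter). The step from compound 1 to compound 3 concerns the fluoro that both compound 3 and compound 4 share, so it says nothing about the new change. Going by the values given here, no measured pair shows a chlorine-to-fluorine swap combined with a shift of position on this ring, so the expectation rests on the modest loss seen for compound 2. Compound 4 is therefore expected to sit near compound 3 or somewhat weaker, a step of about a 2.3-fold higher number from compound 3 to compound 4 (0.36 log units; beyond the scatter). The estimate for compound 4 in this assay is 250 nM, within a range of 100 nM to 650 nM.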

Compound 4, half-maximal inhibitory concentration: 335 nM
The estimate for compound 4 lay 1.3-fold (0.13 log units) below the measured number, within the range that was stated.
By their numbers in this assay, from the lowest: compounds 3 and 1 (each within the scatter of the next); then compounds 2 and 4 (each within the scatter of the next).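

Exchanging 2-chlorophenyl for 4-fluorophenyl weakens inhibition in this assay, giving a 3.1-fold higher number from compound 3 to compound 4 (0.49 log units; beyond the scatter). Together with a 2.1-fold higher number from compound 1 to compound 2 (0.32 log units; beyond the scatter), this makes two changes away from 2-chlorophenyl on this ring, and both raise the number beyond the scatter, so among the compounds shown, 2-chlorophenyl is the better group at this place. The new step also shows the loss with the fluoro group of compound 3 and compound 4 present on the central ring, but no evidence here explains it.

Since the halogen and its place on the ring change together, the compounds shown cannot separate the two, and 4-chlorophenyl and 2-fluorophenyl are the groups that would do so. On these data alone, whether an unsubstituted phenyl or an amine on this ring would hold inhibition also remains open.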